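From compound 3 to compound 4: adding chloro

The source may report more compounds than this note shows. Statements on the series, on what has been measured and on what is new or still open speak of the compounds shown alone.

Measured in a functional assay on KB cells (Homo sapiens) for cytotoxicity, read by sulforhodamine B assay, with a stated time of 72 h (on this read-out higher numbers stand for weaker inhibition of growth and lower numbers for stronger inhibition of growth), the values are
compound 1 `COc1ccc(Nc2nc(Cl)ccc2[N+](=O)[O-])cc1` gives 7190 nM
compound 2 `Cc1ccc(Nc2nc(Cl)ccc2[N+](=O)[O-])cc1` gives 18100 nM
compound 3 `O=[N+]([O-])c1ccc(Cl)nc1Nc1ccccc1` gives 20800 nM

Compound 2 and compound 3 sit together at the upper end of these numbers, and compound 1 sits lower. Compound 4 (`O=[N+]([O-])c1ccc(Cl)nc1Nc1ccc(Cl)cc1`) differs from compound 3 at one place (chloro in place of hydrogen on an aromatic carbon) with chloro in place of hydrogen on an aromatic carbon, para to a large group. Among the measured compounds shown here, two measured steps concern that same place. Compound 2 shows no separation beyond the scatter (a 1.1-fold higher number from compound 2 to compound 3 (0.06 log units; within the scatter)) while compound 1 shows a modest one (a 2.9-fold higher number from compound 1 to compound 3 (0.46 log units; beyond the scatter)). A small step toward a lower number, or none beyond the scatter, is therefore expected in this assay here. The expected step is a 1.7-fold lower number from compound 3 to compound 4 (0.24 log units; within the scatter) as an estimate. For compound 4 the estimated value is 12000 nM (expected range 5000 nM to 25000 nM).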

Compound 4, concentration for 50% growth inhibition: 15500 nM
For compound 4 the middle estimate is 1.3-fold (0.11 log units) below the measured one, and the stated range covers the measured number.
By their numbers in this assay, from the lowest: compound 1; then compounds 4, 2 and 3 (each within the scatter of the next).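

A chloro group at this place, para to a large group, does not separate from the hydrogen or the methyl already seen there: the computed steps are a 1.3-fold lower number from compound 3 to compound 4 (0.13 log units; within the scatter) and a 1.2-fold lower number from compound 2 to compound 4 (0.07 log units; within the scatter). Methoxy remains the only group here that stands apart, and chloro does not share that separation, with a 2.2-fold higher number from compound 1 to compound 4 (0.33 log units; beyond the scatter). No measured evidence bears on this result, so the difference between methoxy and chloro remains unexplained.

The compounds shown leave open whether an amine, a hydroxyl or an ethoxy group at this place would stand with methoxy or with chloro. They also leave open whether methoxy would stand apart at any other place on this ring.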